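Swapping a Piperidine for an Ethylpiperazine

The source may report more compounds than this note shows. Statements on the series, on what has been measured and on what is new or still open speak of the compounds shown alone.

Compound 1 `Cc1nc(Nc2ccc3sc(C(=O)Nc4c(C)cccc4Cl)cc3c2)cc(N2CCCCC2)n1` is the weakest performer among the three compounds with numbers. In a functional assay on U-937 cells (Homo sapiens) for cytotoxicity, read by MTT assay and WST assay, with a stated time of 72 h (on this read-out lower numbers stand for stronger inhibition and higher numbers for weaker inhibition), compound 1 gives 20000 nM. Compound 2 `COc1cc2c(Nc3ccc4sc(C(=O)Nc5c(C)cccc5Cl)cc4c3)ncnc2cc1OCCCN1CCCCC1` gives 4340 nM, and compound 3 `COc1cc2c(Nc3ccc4sc(C(=O)Nc5c(C)cccc5Cl)cc4c3)ncnc2cc1OCCCN1CCN(C)CC1` gives 3480 nM; both sit on a different core from compound 1, so their numbers only indicate that the shared amide portion can reach stronger inhibition in other settings.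

The move to compound 4 `CCN1CCN(c2cc(Nc3ccc4sc(C(=O)Nc5c(C)cccc5Cl)cc4c3)nc(C)n2)CC1` is 4-ethylpiperazin-1-yl in place of piperidin-1-yl on an aromatic carbon. Among the compounds with values here, the only measured step that resembles this exchange is a 1.2-fold lower number from compound 2 to compound 3 (0.10 log units; within the scatter), where a piperidin-1-yl gave way to a 4-methylpiperazin-1-yl, though on a saturated chain carbon rather than on an aromatic carbon. That step did not move the number beyond the scatter. On this basis the expected step of a 1.4-fold lower number from compound 1 to compound 4 (0.15 log units; within the scatter) is small, with at most a slight shift towards stronger inhibition. Compound 4 is therefore estimated at 14000 nM, with a range from 5000 nM to 40000 nM.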

Compound 4, half-maximal inhibitory concentration: 13100 nM
For compound 4 the middle estimate is 1.1-fold (0.03 log units) above the measured one; the range from low to high includes it.
By their numbers in this assay, from the lowest: compounds 3 and 2 (each within the scatter of the next); then compounds 4 and 1 (each within the scatter of the next).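

On the aromatic carbon of the core of compound 1, the exchange of piperidin-1-yl for 4-ethylpiperazin-1-yl gives a 1.5-fold lower number from compound 1 to compound 4 (0.18 log units; within the scatter) in this assay, so this position accepts the added ring nitrogen and its ethyl group without a change beyond the scatter. Until now, a piperidine-to-piperazine exchange had been seen only on a saturated chain carbon, and among the compounds shown it now stays within the scatter at both kinds of attachment point. No measurement at hand accounts for this small step.

As far as these compounds go, it remains open whether morpholine, a simple dimethylamino group or a carboxylic acid on this aromatic carbon would move the number beyond the scatter. From the compounds shown here alone, it is also open whether a piperazine without the ethyl group would read the same as compound 4.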